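A few compounds are considered here, and "the series" means these few. Any claim that something is new, unique, unknown or untested is made for them only; others in the source may bear on it.

Measured in a functional assay on HT-29 cells (Homo sapiens) for inhibition, read by luminescence and CellTiter-Glo, with a stated time of 24 h; a higher number here means that more compound is needed for the effect, a lower number that less compound is needed:
- compound 1 `CCCCn1nc(C(=O)N[C@H]2COc3ccccc3N(C)C2=S)nc1Cc1ccccc1`: 510 nM
- compound 2 `CC(C)Cn1nc(C(=O)N[C@H]2COc3ccccc3N(C)C2=S)nc1Cc1ccccc1`: 1230 nM
- compound 3 `CC(C)CCn1nc(C(=O)N[C@H]2COc3ccccc3N(C)C2=S)nc1Cc1ccccc1`: 3640 nM

Compound 3 has the highest number of the three. Compound 4 `COCCn1nc(C(=O)N[C@H]2COc3ccccc3N(C)C2=S)nc1Cc1ccccc1` differs from compound 3 by one change: methoxy in place of isopropyl on a saturated chain carbon, two bonds along the chain from an aromatic nitrogen. For the measured compounds named here, no measured compound carries methoxy, so the chain steps bear on this change only indirectly: a 2.4-fold higher number from compound 1 to compound 2 (0.38 log units; beyond the scatter), a 3.0-fold higher number from compound 2 to compound 3 (0.47 log units; beyond the scatter) and a 7.1-fold higher number from compound 1 to compound 3 (0.85 log units; beyond the scatter), all modest. With compound 3 at the top of the measured values at 3640 nM, a modest move to a lower number is expected in this assay. The expected step is a 2.4-fold lower number from compound 3 to compound 4 (0.39 log units; beyond the scatter). For compound 4 the estimate is 1500 nM, with an expected range of 350 nM to 6000 nM.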

Compound 4, half-maximal effective concentration: 566 nM
For compound 4 the middle estimate is 2.7-fold (0.42 log units) above the measured one, and the stated range covers the measured number.
By their numbers in this assay, from the lowest: compounds 1 and 4 (each within the scatter of the next); then compound 2; then compound 3.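

On this chain, methoxy in place of isopropyl gives a 6.4-fold lower number from compound 3 to compound 4 (0.81 log units; beyond the scatter) and methoxymethyl in place of isopropyl gives a 2.2-fold lower number from compound 2 to compound 4 (0.34 log units; beyond the scatter), so the higher numbers among the four compounds belong to the two branched chains, with no compound shown going against this. Methoxy in place of ethyl gives a 1.1-fold higher number from compound 1 to compound 4 (0.05 log units; within the scatter), so the unbranched chains of these two compounds are not told apart, and an oxygen is tolerated in this chain. Nothing available gives a cause for these steps.

Open, on these data alone, is whether an amine or a carboxylic acid at the chain end would keep the number of compound 4 566 nM in this range. As far as these compounds go, a longer ether chain also remains open.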